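Series notes: compounds 1 to 4, one measurement pending

The compounds below may be only part of what the source reports. "The series", "measured", "known", "first", "only" and "open" are said of these compounds alone.

Measured so far in a functional assay on cells for positive allosteric modulation of G-protein coupled receptor 68 (Homo sapiens), read by a luciferase reporter and cAMP accumulation, with a stated time of 30 min, at pH 6.8 and pH 8.3, in the presence of a further agent that is not named here; on this read-out lower numbers stand for lower potency and higher numbers for higher potency (the scale is a negative logarithm):
compound 1, `NCc1ccccc1-c1nc(N)nc(NCc2ccccc2)n1`, gives 3.86
compound 2, `Nc1nc(NCc2ccccc2)nc(-c2c(F)cccc2CO)n1`, gives 3.69
compound 3, `Nc1nc(NCc2cccc(F)c2)nc(-c2ccccc2CO)n1`, gives 4.52
compound 4, `COc1ccc(CNc2nc(N)nc(-c3ccccc3CO)n2)cc1`, not yet measured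

Compound 3 holds the highest of the three numbers in this assay. Its nearest neighbour is compound 1, whose number stands lower by a margin beyond the scatter; compound 2 stands furthest, also beyond the scatter. Compound 1 and compound 2 differ only in a way not counted here, and nothing is known of any step between them beyond what the two values show.

Compound 4 is reached from compound 3 by a single change: 4-methoxyphenyl in place of 3-fluorophenyl on a saturated chain carbon bound to a nitrogen on an aromatic ring. For the measured compounds named here, no measured pair in the set carries this same exchange, so the size of the step cannot be read from a known difference. Compound 1, which carries no group at all on that ring, sits well below compound 3, so the added group in compound 3 appears to matter; its replacement by 4-methoxyphenyl is expected to cost some of that gain rather than add to it. The step from compound 3 to compound 4 in this assay is therefore expected to be a number 0.32 log units lower from compound 3 to compound 4 (beyond the scatter), a modest fall, not clearly beyond the scatter. Compound 4 is estimated at 4.2, with a plausible range from 3.6 to 4.8.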

Compound 4, negative logarithm of the antagonist equilibrium constant: 3.34
Compound 4: the middle estimate sits 0.86 log units above what was measured, outside the stated range (below it).
By their numbers in this assay, from the lowest: compound 4; then compounds 2 and 1 (each within the scatter of the next); then compound 3.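

In this assay, 4-methoxyphenyl in place of 3-fluorophenyl on a saturated chain carbon bound to a nitrogen on an aromatic ring gives a number 1.18 log units lower from compound 3 to compound 4 (beyond the scatter), a large step and the first one in the series that can be read at a single place. The read-out at this position therefore depends strongly on the group it carries: an exchange that keeps one six-membered aromatic ring of carbon only, and moves from 7 heavy atoms to 8 and from 0 hydrogen-bond acceptors to 1, is enough to produce a fall well beyond the scatter. The data offer no measurement that accounts for the size of this fall.

For the compounds shown here, the single pair changes the substituent and its place on the ring together, so it remains open whether the fall follows the methoxy group, the loss of fluorine or the new location. Also open, on these data alone, is how a pyridine ring, a cyclohexyl group or a longer chain would read at this place in this assay, and whether any of them would hold or exceed the level of compound 3.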